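The compounds below may be only part of what the source reports. "The series", "measured", "known", "first", "only" and "open" are said of these compounds alone.

Going by the values given here, compound 1 `CC(=O)Nc1cccc(Cn2cc(-c3ccc4cn[nH]c4c3)ccc2=O)c1` is one of two compounds measured in an assay for inhibition of MAP kinase-interacting serine/threonine-protein kinase 1 (Homo sapiens), read by luminescence and ADP-Glo, with a stated time of 2 h; on this read-out higher numbers stand for weaker inhibition and lower numbers for stronger inhibition. Compound 1 gives 163 nM, the highest of the two numbers. Among the compounds with values here, its nearest neighbour, compound 2 `O=c1ccc(-c2n[nH]c3ncc(Br)cc23)cn1Cc1ccccc1`, gives 56 nM in this assay, a lower number that lies beyond the scatter; compound 2 differs from compound 1 in several places at once, so the two values show only that compound 2 is the stronger inhibitor here, not which change is responsible.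

Compound 3 `O=c1ccc(-c2ccc3cn[nH]c3c2)cn1Cc1ccccc1` is not yet measured. It differs from compound 1 in one place: hydrogen in place of acetamido on an aromatic carbon, on an aromatic carbon of a six-membered aromatic ring of carbon only, meta to a large group. Within the data shown here, no single-change step is available to guide the expectation, so the estimate leans on compound 1 alone. The step of a 1.4-fold higher number from compound 1 to compound 3 (0.15 log units; within the scatter) is expected to be small, not beyond the scatter. Compound 3 is estimated at 230 nM in this assay, within 80 nM to 700 nM.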

Compound 3, half-maximal inhibitory concentration: 315 nM
Compound 3: middle estimate off by 1.4-fold (0.14 log units), on the low side, and the stated range covers the measured number.
By their numbers in this assay, from the lowest: compound 2; then compounds 1 and 3 (each within the scatter of the next).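

In this assay, going by these compounds alone, the exchange of acetamido for hydrogen on an aromatic carbon, meta to a large group, gives a 1.9-fold higher number from compound 1 to compound 3 (0.29 log units; within the scatter) and so provides the first reading of this position through a single change. Compound 3 lacks the acetamido with its 4 heavy atoms, its hydrogen-bond donor and its hydrogen-bond acceptor, yet the two compounds cannot be told apart on this read-out, so the group is not shown to matter for the number at this position. Nothing at hand bears on why the step has this size. 

Going by these compounds, whether another group on this aromatic carbon, such as an amine or a carboxylic acid, would move the number beyond the scatter remains open. Also open, on these data alone, is whether the same exchange would give a step of this size on a core other than that of compound 1.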